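A Bromophenyl Group Enters the Side Chain of Compound 1

The source may hold more compounds than are shown below. What is called first, only, known or untested is meant among the compounds shown, and "the series" means these compounds.

Measured compounds:
compound 1, `C=C1CC[C@@H]2[C@](C)(CO)[C@H](O)CC[C@@]2(C)[C@@H]1/C=C/C1=C/C(=C/C)OC1=O`: 15.1%
compound 2, `C=C1CC[C@@H]2[C@](C)(CO)[C@H](O)CC[C@@]2(C)[C@@H]1/C=C/C1=C/C(=C/CCC)OC1=O`: 43.5%
compound 3, `C=C1CC[C@@H]2[C@](C)(CO)[C@H](O)CC[C@@]2(C)[C@@H]1/C=C/C1=C/C(=C/c2ccc(F)cc2)OC1=O`: "not active" (no number reported)

In an assay on isolated protein for inhibition of Maltase-glucoamylase (Homo sapiens), tested at 100 uM (a lower number here means less inhibition, a higher number more inhibition at the concentration tested (going by the name of the read-out)), compound 1 gives 15.1% and stands lowest of the two numbers reported; its nearest neighbour is compound 2, which gives 43.5% in this assay. Among the compounds with values here, the one step between measured compounds, a number 28.4 percentage points higher from compound 1 to compound 2 (beyond the scatter), comes from ethyl in place of hydrogen on a saturated chain carbon bound to a double-bonded chain carbon. Compound 3 carries an aromatic ring at the end of the same side chain and is reported in this assay as "not active" (no number reported), without a number.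

Compound 4, `C=C1CC[C@@H]2[C@](C)(CO)[C@H](O)CC[C@@]2(C)[C@@H]1/C=C/C1=C/C(=C/c2cccc(Br)c2)OC1=O`, has not yet been measured. It differs from compound 1 by 3-bromophenyl in place of methyl on a double-bonded chain carbon bound to a double-bonded ring carbon. The measured step concerns a different position and a small alkyl group, so it bears only loosely on this change. The nearest comparison is compound 3, whose result in this assay gives no number, and it points toward weak inhibition for an aryl group at this place. Compound 4 is therefore expected to stay near the low end, with a number 5.1 percentage points lower from compound 1 to compound 4 (within the scatter) as the estimated step. For compound 4 the estimate in this assay is 10%, in the range 0% to 30%.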

Compound 4, a percentage reported as inhibition, at one concentration (the size of the read-out at that concentration, not a potency): 16.7%
Compound 4: the middle estimate sits 6.7 percentage points below what was measured; low and high end bracket the measured number.
By their numbers in this assay, from the lowest: compounds 1 and 4 (each within the scatter of the next); then compound 2.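

In this assay, putting 3-bromophenyl in place of methyl on a double-bonded chain carbon bound to a double-bonded ring carbon leaves the read-out within the scatter, with a number 1.6 percentage points higher from compound 1 to compound 4 (within the scatter), while replacing propyl at the same place gives a number 26.8 percentage points lower from compound 2 to compound 4 (beyond the scatter), so the larger group does not keep the level reached with the propyl chain. Compound 3 also has an aromatic ring at this place and is reported as "not active" (no number reported), whereas compound 4 gives 16.7%, which shows that an aromatic ring here does not always leave the result without a number. Nothing available explains why the aryl group and the propyl chain differ in this way.

The compounds shown leave open whether a chain longer than propyl, such as pentyl or hexyl, would give a higher number than compound 2 does. They also leave open what a phenyl ring without bromine, or a phenyl ring carrying an amine or a carboxylic acid, would give at this place.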